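Bromo in place of iodo on a two-ring core

This account rests on a few compounds, and the source may have more. Where it says the series, first, only, none or still open, it means among the compounds named here.

The study groups two measured compounds and one still awaiting a number. Compound 1, `C=Cc1nc(C(=O)OCC)cs1`, was tested in a functional assay on NCI-H522 cells (Homo sapiens) for cytotoxicity, with a stated time of 3 days; a higher number here means a weaker inhibitor, a lower number a stronger inhibitor. In this assay compound 1 gives only a limit, > 40000 nM, which is not a measured number. Compound 2, `Ic1nc2ccccc2o1`, gives a value in this assay of 11700 nM. Compound 2 thus holds the only actual number shown, since the other entry is the limit (the limit of > 40000 nM in this assay, at which 1 of the 2 values shown sits), and no step of comparison can be drawn from a limit alone. Compound 3, `Brc1nc2ccccc2o1`, differs from compound 2 in one place: bromo in place of iodo on an aromatic carbon. Compound 3 is yet to be measured in this assay. Within the data shown here, with no measured step available to guide the size of this change, the expectation rests on the value of compound 2 alone. The step from compound 2 to compound 3 is estimated at a 1.3-fold higher number from compound 2 to compound 3 (0.11 log units; within the scatter), which is expected to stay within the usual scatter of this assay. Compound 3 is therefore estimated to give 15000 nM in this assay, with an expected range from 6000 nM to 40000 nM.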

Compound 3, half-maximal inhibitory concentration: > 40000 nM
Compound 3 was reported as a limit; the forecaster's own chance of this, stated with the estimate: 25%; middle value at least 2.6-fold (0.42 log units) from the limit.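

Among these compounds, this is the first step the set allows, and it shows that the position is not indifferent to the halogen. In this assay, bromo in place of iodo, on an aromatic carbon next to the ring nitrogen and next to the ring oxygen, gives an at least 3.4-fold higher number from compound 2 to compound 3 (0.53 log units; beyond the scatter), even though the exchange swaps one heavy atom for one heavy atom and the counts of rings, donors, acceptors and charge stay the same. Within this pair, the measured number goes with iodo, but the step has only a lower bound, as compound 3 is reported as a limit and compound 2 remains the only compound with an actual number: the limit of > 40000 nM in this assay, at which 2 of the 3 values shown sit.

The compounds shown leave open whether iodo is alone in giving a measured number at this carbon, a question that chloro, an amine or a carboxylic acid at the same place would address. They also leave open how far compound 3 lies beyond its limit, and whether the same exchange would have a similar effect on a different core.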